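A Change on the Chain Nitrogen of Compound 2

The compounds below may be only part of what the source reports. "The series", "measured", "known", "first", "only" and "open" are said of these compounds alone.

Compound 1 `COc1ccc(Oc2ccccc2-c2ccsc2S(=O)(=O)N2CCN(C(=O)Nc3ccc([N+](=O)[O-])cc3)CC2)cc1OC` was tested in a functional assay on RS4-11 cells (Homo sapiens) for inhibition, read by CCK-8 assay, with a stated time of 48 h; a lower number here means a stronger inhibitor, a higher number a weaker inhibitor. For compound 1 the assay reports only a limit, > 50000 nM. Compound 3 `COc1ccc(Oc2ccccc2-c2ccsc2S(=O)(=O)N2CCN(C(=O)Nc3cccc([N+](=O)[O-])c3)CC2)cc1OC` likewise yields only a limit, > 50000 nM. The change a step that the two limits leave unreadable from compound 1 to compound 3 therefore cannot be sized. Within the data shown here, compound 2 `Cc1ccc(-c2ccsc2S(=O)(=O)NCCNC(=S)Nc2ccc([N+](=O)[O-])cc2)c(Oc2ccc(O)c(O)c2)c1` gives 5100 nM, the only number among the three. The other two values sit at the limit of > 50000 nM in this assay, at which 2 of the 3 values shown sit, so compound 2 stands alone as a readable point.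

Compound 4 `Cc1ccc(-c2ccsc2S(=O)(=O)NCCNC(=O)Nc2cc(Cl)cc(Cl)c2)c(Oc2ccc(O)c(O)c2)c1` differs from compound 2 in one place: a group of 11 heavy atoms (7 carbon, 1 nitrogen, 1 oxygen, 2 chlorine; one six-membered aromatic ring of carbon only) in place of a group of 12 heavy atoms (7 carbon, 2 nitrogen, 2 oxygen, 1 sulfur; one six-membered aromatic ring of carbon only), on an amine nitrogen. Among the measured compounds shown here, no measured step touches this kind of change, so neither direction nor size can be read from the data. Compound 4 is accordingly expected at 5500 nM, ranging from 1500 nM to 25000 nM. The expected step of a 1.1-fold higher number from compound 2 to compound 4 (0.03 log units; within the scatter) stays within the usual scatter.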

Compound 4, half-maximal inhibitory concentration: 5100 nM
Beside the measured number, compound 4's estimate is 1.1-fold (0.03 log units) above it, within the range that was stated.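

In this assay, among these compounds, the exchange for (3,5-dichlorophenyl)carbamoyl gives no change at the digits printed from compound 2 to compound 4 (within the scatter) on this amine nitrogen, the first readable step at this position. The two compounds read alike even though the entering group carries chlorine and the leaving group carries sulfur and more nitrogen and oxygen. Nothing measured here explains this match.

With several atoms exchanged in one step, the share of the sulfur and that of the ring chlorines cannot be separated. On these data alone, how a carboxylic acid on that ring, or a longer chain on this nitrogen, would read remains open.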